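Two measured compounds and an untested amide

This account rests on a few compounds, and the source may have more. Where it says the series, first, only, none or still open, it means among the compounds named here.

Values from a functional assay on NCI-H460 cells (Homo sapiens) for cytotoxicity, read by MTT assay, with a stated time of 72 h (on this read-out lower numbers stand for stronger inhibition and higher numbers for weaker inhibition), stand as follows

Compound 1 `COc1cc(/C=C2\CN(C)C/C(=C\c3cc(OC)c(OC)c(OC)c3)C2=O)cc(OC)c1OC` gives 1000 nM 
Compound 2 `COc1ccc(/C=C2\CN(C)C/C(=C\c3ccc(OC)c(OC)c3)C2=O)cc1OC` gives 3100 nM 

Of these two, compound 1 has the lower number, and the gap up to compound 2 lies beyond the usual scatter. Compound 1 is therefore the natural starting point for the next comparison.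

Compound 3 `COc1cc(/C=C2\CN(C(=O)c3ccccc3F)C/C(=C\c3cc(OC)c(OC)c(OC)c3)C2=O)cc(OC)c1OC` keeps the core of compound 1 but has (2-fluorophenyl)carbonyl in place of methyl on an amine nitrogen in a ring. This is a large change at a single place. Among the measured compounds shown here, no measured pair covers it, so the data offer no direct guide to its size or direction in this assay, and any forecast is a judgment.

Starting from compound 1 at 1000 nM, a moderate gain is expected rather than a collapse of activity. The expected change is a 2.5-fold lower number from compound 1 to compound 3 (0.40 log units; beyond the scatter), which would point toward stronger inhibition and would probably lie beyond the scatter. For compound 3 the estimated value is 400 nM, with an expected range from 100 nM to 1600 nM.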

Compound 3, half-maximal inhibitory concentration: 1500 nM
For compound 3 the middle estimate is 3.8-fold (0.57 log units) below the measured one, within the range that was stated.
By their numbers in this assay, from the lowest: compounds 1 and 3 (each within the scatter of the next); then compound 2.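

Placing (2-fluorophenyl)carbonyl in place of methyl on an amine nitrogen in a ring gives a 1.5-fold higher number from compound 1 to compound 3 (0.18 log units; within the scatter) in this assay and so leaves compound 1 and compound 3 indistinguishable on this read-out. Compounds 1 and 2 both carry methyl on this nitrogen and could say nothing about this place, whereas this pair shows that a far larger group, bringing a six-membered aromatic ring and a carbonyl, can stand there with no loss beyond the scatter. Nothing measured on these compounds accounts for this outcome.

The compounds shown leave open what each part of the new group contributes, since a plain benzoyl group without the fluorine, an acetyl group or a simple benzyl group on the same nitrogen would be needed to separate the aromatic ring, the carbonyl and the fluorine. Also open, on these data alone, is whether the same replacement would give a similar result on the core of compound 2, which differs from compound 1 in its aryl groups.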